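Aryl swap on the shared core: thiophene to phenyl

The compounds below may be only part of what the source reports. "The series", "measured", "known", "first", "only" and "open" are said of these compounds alone.

Working notes on two measured compounds and one open position. In a functional assay on K562 cells (Homo sapiens), read by MTT assay, with a stated time of 72 h (on this read-out lower numbers stand for stronger inhibition and higher numbers for weaker inhibition), compound 1 `CSc1ncnc2c1c(-c1ccccc1)cn2[C@@H]1O[C@H](CO)[C@@H](O)[C@H]1O` reports only a limit, > 20000 nM, and not a number. Compound 2 `COc1ncnc2c1c(-c1cccs1)cn2[C@@H]1O[C@H](CO)[C@@H](O)[C@H]1O` gives 6200 nM in this assay. Compound 2 therefore stands as the only number shown; the remaining value is the limit of > 20000 nM in this assay, at which 1 of the 2 values shown sits.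

Compound 3 `COc1ncnc2c1c(-c1ccccc1)cn2[C@@H]1O[C@H](CO)[C@@H](O)[C@H]1O` has not been measured in this assay. It differs from compound 2 by phenyl in place of thiophen-2-yl on an aromatic carbon. Compound 1 also bears a phenyl on the shared core and reports only the limit > 20000 nM. On that basis the step from compound 2 to compound 3 is expected to weaken inhibition, a 2.3-fold higher number from compound 2 to compound 3 (0.35 log units; beyond the scatter), a move beyond the usual scatter rather than within it. Compound 3 is estimated at 14000 nM in this assay, with a range from 5000 nM to 40000 nM, and a fair chance that only a limit is returned.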

Compound 3, half-maximal inhibitory concentration: > 20000 nM
Compound 3 was reported as a limit; the forecaster's own chance of this, stated with the estimate: 40%; middle value at least 1.4-fold (0.15 log units) from the limit.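

With methoxy held constant, phenyl in place of thiophen-2-yl on this aromatic carbon can now be read directly in this assay: an at least 3.2-fold higher number from compound 2 to compound 3 (0.50 log units; beyond the scatter), a single-change comparison that compound 1 and compound 2, which differ in two places, could not give. Compound 3 gives > 20000 nM, which is a limit and not a number. The change from methylsulfanyl to methoxy between the two phenyl compounds cannot be read, and compound 1 and compound 3 sit at the same limit: the limit of > 20000 nM in this assay, at which 2 of the 3 values shown sit.

From the compounds shown here alone, whether furan-2-yl, thiophen-3-yl or pyridin-2-yl on this carbon would return a number, as thiophen-2-yl does in compound 2, remains open. Also open, going by these compounds, is how an amine or a longer alkoxy chain in place of the methoxy would read in this assay with thiophen-2-yl kept on the shared core.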